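Aryl-chain variation on the shared core: A3 displacement notes

The source may report more compounds than this note shows. Statements on the series, on what has been measured and on what is new or still open speak of the compounds shown alone.

Compound 2 `Nc1nc(Cc2ccc(O)cc2)nc2cn(-c3ccccc3)nc12` is the lower of the two measured numbers in an assay on CHO cells for displacement of a labelled ligand from adenosine receptor A3 (Homo sapiens), read by scintillation counting, tested at 1 uM (on this read-out lower numbers stand for less inhibition and higher numbers for more inhibition at the one concentration tested (going by the name of the read-out)), where compound 2 gives 20%. For the measured compounds named here, its nearest neighbour is compound 1 `Nc1nc(Cc2ccccc2Cl)nc2cn(-c3ccccc3)nc12`, which in this assay gives 22%; the only measured step, a number 2 percentage points lower from compound 1 to compound 2 (within the scatter), lies within the scatter, so the two compounds are indistinguishable on this read-out.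

Compound 3 `Nc1nc(CCc2ccccc2)nc2cn(-c3ccccc3)nc12` is not yet measured. Its change from compound 2 is benzyl in place of 4-hydroxyphenyl on a saturated chain carbon bound to an aromatic carbon. Going by the values given here, the one measured step bears on it only loosely: the exchange of one aryl group for another on the same saturated chain carbon, from compound 1 to compound 2, moved this assay by a step within the scatter. Among the compounds with values here, no measured step removes the hydroxyl or lengthens the chain, so there is nothing to point to a step beyond the scatter in either direction.

Compound 3 is therefore expected to sit near the two measured numbers, at an estimated 21% with a range of 6% to 38%. The expected step of a number 1 percentage points higher from compound 2 to compound 3 (within the scatter) is estimated to stay within the scatter.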

Compound 3, a percentage reported as inhibition, at one concentration (the size of the read-out at that concentration, not a potency): 17%
The estimate for compound 3 lay 4 percentage points above the measured number; low and high end bracket the measured number.
By their numbers in this assay, from the lowest: compounds 3, 2 and 1 (each within the scatter of the next).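

In this assay, benzyl in place of 4-hydroxyphenyl on a saturated chain carbon bound to an aromatic carbon gives a number 3 percentage points lower from compound 2 to compound 3 (within the scatter), and benzyl in place of 2-chlorophenyl at the same place gives a number 5 percentage points lower from compound 1 to compound 3 (within the scatter). The same difference, read as 4-hydroxybenzyl to phenethyl, removes the hydroxyl and lengthens the chain at once, yet compound 3 stays within the scatter of both earlier compounds, so this position now shows a change of chain length as well as an exchange of aryl groups without any separation on this read-out. No supporting data bear on this result, and the absence of separation stands as an observation only.

On these data alone, whether an amine or a carboxylic acid on the aryl ring, or a chain longer than phenethyl, would move the number beyond the scatter remains open. Each number comes from one concentration, and the three compounds remain unranked in potency. The separate contributions of the hydroxyl and the chain length in the step to compound 3 cannot be told apart.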